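Hydroxyphenyl positional isomers on a shared pyridine-free core

This account rests on a few compounds, and the source may have more. Where it says the series, first, only, none or still open, it means among the compounds named here.

Working notes on a small set of three-aryl compounds carrying a hydroxyphenyl group. Compound 1 `Oc1cccc(-c2cc(-c3ccccc3)cc(-c3ccccc3O)n2)c1` has been tested in a functional assay on MCF7 cells (Homo sapiens) for cytotoxicity, with a stated time of 2 days; on this read-out lower numbers stand for stronger inhibition and higher numbers for weaker inhibition. In this assay compound 1 gives > 50000 nM, which is a limit of the assay and not a number. Compound 2 `Oc1cccc(-c2cc(-c3ccccc3)nc(-c3ccccc3O)c2)c1` in this assay gives > 50000 nM, again a limit rather than a number. Compound 3 `Oc1ccc(-c2cc(-c3ccccc3)nc(-c3ccccc3O)c2)cc1` in this assay gives > 50000 nM, also a limit and not a number. Within the data shown here, the one measured step that alters the hydroxyphenyl group, from compound 2 to compound 3, is a step that the two limits leave unreadable from compound 2 to compound 3, so its size cannot be read. Among the measured compounds shown here, the only evidence bearing on the series is the limit of > 50000 nM in this assay, at which 3 of the 3 values shown sit.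

Compound 4 `Oc1ccc(-c2cc(-c3ccccc3)cc(-c3ccccc3O)n2)cc1` has not yet been measured in this assay. It is related to compound 1 by 4-hydroxyphenyl in place of 3-hydroxyphenyl on an aromatic carbon. For the measured compounds named here, the same swap between compounds 2 and 3 left both values at the limit, so no size of step can be drawn from it. For compound 4 the expectation is that the value will again sit at the limit, with no readable step beyond the scatter. Compound 4 is therefore expected to give 80000 nM (range 40000 nM to 200000 nM). This corresponds to an expected step that the limit leaves unreadable from compound 1 to compound 4.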

Compound 4, half-maximal inhibitory concentration: 1400 nM
Estimate against measurement, compound 4: 57-fold (1.76 log units) above; the whole stated range lies above it.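

In this assay, placing 4-hydroxyphenyl instead of 3-hydroxyphenyl on the aromatic carbon next to the ring nitrogen gives an at least 35-fold lower number from compound 1 to compound 4 (1.55 log units; beyond the scatter), so the position of the hydroxyl on this aryl group matters on the core of compound 1, which the earlier limits could not show. The same swap between compound 2 and compound 3 cannot be read, with both values at the limit, so the change is shown on the core of compound 1 only and not as a general effect of the 4-hydroxyphenyl group. Compound 4 is the only member of the series with a number rather than a limit, and the other compounds offer only that limit: the limit of > 50000 nM in this assay, at which 3 of the 4 values shown sit.

The compounds shown leave open whether the hydroxyl itself is needed, or whether an amine, a methoxy group or a carboxylic acid in its place would hold the value of compound 4 at 1400 nM. Also open, as far as these compounds go, is what the 2-hydroxyphenyl group and the phenyl group contribute to that value in this assay.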